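This account rests on a few compounds, and the source may have more. Where it says the series, first, only, none or still open, it means among the compounds named here.

Measured so far:
Compound 1, `CC(C)c1ccccc1NC(=O)[C@@H]1CCCN1S(=O)(=O)c1cccc2cccnc12`: 29900 nM
Compound 2, `Cc1ccc(C(F)(F)F)cc1NC(=O)[C@@H]1CCCN1S(=O)(=O)c1cccc2cccnc12`: 4800 nM

Both compounds were tested in an ADME assay on HEp-2 cells (Homo sapiens) for cytotoxicity; a higher number here means that more compound is tolerated, a lower number that less compound is tolerated. Compound 1 stands at the higher of the two numbers, meaning HEp-2 cells tolerate more of it, and compound 2 lies clearly below it, a gap beyond the usual scatter. Among the measured compounds shown here, no pair of measured compounds differs in only one place, so no single change has yet been followed on its own.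

Compound 3, `Cc1ccc(Cl)c(NC(=O)[C@@H]2CCCN2S(=O)(=O)c2cccc3cccnc23)c1`, has not been measured. It differs from compound 1 in one way: 2-chloro-5-methylphenyl in place of 2-isopropylphenyl on an amide-type nitrogen. Because compound 2, which also carries a different substituted phenyl on the same amide nitrogen, gives 4800 nM, the expected downward step is estimated as a 2.3-fold lower number from compound 1 to compound 3 (0.36 log units; beyond the scatter), smaller than that gap and only modest in size. Compound 3 is therefore estimated at 13000 nM, with a plausible range from 4500 nM to 38000 nM.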

Compound 3, half-maximal cytotoxic concentration: > 50000 nM
Compound 3: no number, only a limit (the forecaster's own chance of this, stated with the estimate: 10%); middle value at least 3.8-fold (0.58 log units) from the limit.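

Compound 3 gives only a limit in this assay, > 50000 nM, rather than a number. Putting 2-chloro-5-methylphenyl in place of 2-isopropylphenyl on the amide-type nitrogen gives an at least 1.6-fold higher number from compound 1 to compound 3 (0.22 log units; that floor lies within the scatter), so this first change followed on its own shows no drop in the amount of compound tolerated, although the floor of the step does not clear the usual scatter. How large the step really is stays unknown because the value is a limit: the limit of > 50000 nM in this assay, at which 1 of the 3 values shown sits.

Going by these compounds, it remains open how the cells would respond to a phenyl ring carrying a carboxylic acid or an amine at this same place on the amide-type nitrogen. Also open, on these data alone, is whether the result would hold on a different core, since these compounds share one.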